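A few compounds are considered here, and "the series" means these few. Any claim that something is new, unique, unknown or untested is made for them only; others in the source may bear on it.

The compounds share one core, seen in compound 1 `CCc1cccc2c(O)c(-c3occ(C)c3C(=O)O)ccc12`. In a functional assay on MDA-MB-231 cells (Homo sapiens) for cytotoxicity, read by MTT assay, with a stated time of 72 h (a higher number here means that more compound is needed for the effect, a lower number that less compound is needed), compound 1 gives 0.3 ug/mL. Compound 2 `CCOc1c(-c2occ(C)c2C(=O)O)ccc2c(CC)cccc12` carries an ethyl in place of hydrogen on an oxygen on an aromatic ring. In this assay compound 2 reaches only > 10 ug/mL, which is a limit of the assay and not a number (the limit of > 10 ug/mL in this assay, at which 1 of the 3 values shown sits). Taken as a step, this is an at least 33-fold higher number from compound 1 to compound 2 (1.52 log units; beyond the scatter). Compound 3 `CCc1cccc2c(OC)c(-c3occ(C)c3COCC(F)(F)F)ccc12` carries a methyl on that oxygen and an ether chain in place of the carboxy; in this assay compound 3 gives 5.3 ug/mL.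

Compound 4 `CCOc1c(-c2occ(C)c2COC)ccc2c(CC)cccc12` is not yet measured. It differs from compound 2 in one place: methoxymethyl in place of carboxy on an aromatic carbon. For the measured compounds named here, no measured step covers this change; the one measured step, an at least 33-fold higher number from compound 1 to compound 2 (1.52 log units; beyond the scatter), concerns the oxygen, not the carboxy. Compound 3 shows that a compound with an alkylated oxygen and an ether in place of the carboxy can give a number rather than a limit. Compound 4 is expected near 8 ug/mL, between 3 ug/mL and 25 ug/mL, an expected step of an at least 1.2-fold lower number from compound 2 to compound 4 (0.09 log units; that floor lies within the scatter), with a fair chance that only a limit is again reported.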

Compound 4, concentration for half-maximal effect: > 10 ug/mL
Compound 4 ended at the assay's limit (the forecaster's own chance of this, stated with the estimate: 40%); middle value at least 1.2-fold (0.09 log units) away from the limit.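

Compound 2 and compound 4 both end at a limit of the assay and not at a number, so no step between them can be read: the limit of > 10 ug/mL in this assay, at which 2 of the 4 values shown sit.

The compounds shown leave open whether methoxymethyl in place of carboxy changes the result at all in this assay when an ethyl sits on the oxygen.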